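Removing the amino group: compound 3 to compound 4

The source may hold more compounds than are shown below. What is called first, only, known or untested is meant among the compounds shown, and "the series" means these compounds.

Measured so far in a functional assay on Jurkat cells (Homo sapiens) for antiproliferative activity, read by MTT assay, with a stated time of 72 h; a higher number here means a weaker inhibitor, a lower number a stronger inhibitor:
compound 1 `COc1cc(-n2ncnc2-c2cccc([N+](=O)[O-])c2)cc(OC)c1OC`: > 10000 nM
compound 2 `COc1cc(-n2ncnc2-c2ccc(OC(C)C)cc2)cc(OC)c1OC`: 650 nM
compound 3 `COc1cc(-c2ncnn2-c2cccc(N)c2)cc(OC)c1OC`: > 10000 nM

Compound 3 `COc1cc(-c2ncnn2-c2cccc(N)c2)cc(OC)c1OC` is known only as a limit in this assay, where compound 3 gives > 10000 nM and no number. Compound 1 also sits at a limit, > 10000 nM. Of the three values shown, two therefore rest at the limit of > 10000 nM in this assay, at which 2 of the 3 values shown sit, and only compound 2, with its isopropoxy group, gives a number, 650 nM.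

Compound 4 `COc1cc(-c2ncnn2-c2ccccc2)cc(OC)c1OC` is not yet measured. It differs from compound 3 by hydrogen in place of amino on an aromatic carbon. Going by the values given here, no step between two measured compounds is known here, so the size of the change cannot be read from the series itself. The expectation is a step toward stronger inhibition in this assay, since compound 2 with an uncharged ether group gives 650 nM. Compound 3 itself is known only as a limit. Among the compounds with values here, the expected step of an at least 3.3-fold lower number from compound 3 to compound 4 (0.52 log units; beyond the scatter) rests on no measured step and is uncertain. For compound 4 the estimate in this assay is 3000 nM, within 700 nM to 12000 nM.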

Compound 4, half-maximal inhibitory concentration: > 10000 nM
Compound 4: no number, only a limit; the forecaster's own chance of this, stated with the estimate: 40%; at least 3.3-fold (0.52 log units) between middle value and limit.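

Going by these compounds alone, compound 3 and compound 4 in this assay both rest at a limit of the assay, so no step between them can be read: the limit of > 10000 nM in this assay, at which 3 of the 4 values shown sit.

The compounds shown leave open whether hydrogen in place of amino on an aromatic carbon changes the result in this assay at all.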